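Working notes: aryl change from compound 3 to compound 4

The compounds below may be only part of what the source reports. "The series", "measured", "known", "first", "only" and "open" are said of these compounds alone.

Values in a functional assay on PANC-1 cells (Homo sapiens) for inhibition, read by MTT assay, with a stated time of 24 h (on this read-out higher numbers stand for weaker inhibition and lower numbers for stronger inhibition), follow
- compound 1 `COc1ccccc1-n1cc(CN2C(=O)C[C@@H]3CC[C@@]2(C)C3(C)C)nn1` gives 120 nM
- compound 2 `CC1(C)[C@H]2CC[C@]1(C)N(Cc1cn(-c3ccccc3O)nn1)C(=O)C2` gives 230 nM
- compound 3 `CC1(C)[C@H]2CC[C@]1(C)N(Cc1cn(-c3ccc(Cl)cc3)nn1)C(=O)C2` gives 440 nM

Compound 3 lies within the scatter of compound 2, while compound 1 shows a lower number beyond the scatter. Compound 4 `Cc1cccc(-n2cc(CN3C(=O)C[C@@H]4CC[C@@]3(C)C4(C)C)nn2)c1` carries 3-methylphenyl in place of 4-chlorophenyl on an aromatic nitrogen with the shared core unchanged. Two measured aryl replacements bear on this change: a 3.7-fold higher number from compound 1 to compound 3 (0.56 log units; beyond the scatter) is modest and a 1.9-fold higher number from compound 2 to compound 3 (0.28 log units; within the scatter) stays within the scatter. Among the compounds with values here, no measured compound carries 3-methylphenyl, so no step beyond the scatter is expected in this assay and only a slightly lower number is anticipated. The expected step is a 1.5-fold lower number from compound 3 to compound 4 (0.17 log units; within the scatter) and remains tentative. Compound 4 is estimated at 300 nM (expected range 120 nM to 750 nM).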

Compound 4, half-maximal inhibitory concentration: 240 nM
Beside the measured number, compound 4's estimate is 1.3-fold (0.10 log units) above it, and the stated range covers the measured number.
By their numbers in this assay, from the lowest: compounds 1, 2, 4 and 3 (each within the scatter of the next, the first and the last beyond it).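

The 3-methylphenyl group, an aryl group of carbon only, stays within the scatter of all three earlier aryl groups in this assay, with a 1.8-fold lower number from compound 3 to compound 4 (0.26 log units; within the scatter) and a 1.0-fold higher number from compound 2 to compound 4 (0.02 log units; within the scatter) and a 2.0-fold higher number from compound 1 to compound 4 (0.30 log units; within the scatter) as the steps. Within the data shown here, an oxygen on the aryl ring is therefore not needed for a value within the scatter of compound 1, and compound 3 remains the only compound beyond the scatter of compound 1. No evidence on the reason for these steps is available.

The step from 4-chlorophenyl to 3-methylphenyl changes both the substituent and its place on the ring, and the two effects cannot be separated. On these data alone, how an amine or a carboxylic acid on the aryl ring would read out remains open.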